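Removal of the aromatic amino group: expected effect on potency

This account rests on a few compounds, and the source may have more. Where it says the series, first, only, none or still open, it means among the compounds named here.

Measured compounds:
compound 1 `Nc1ccc(C(=O)NN=C(c2ccccn2)c2ccccn2)cc1` — in an ADME assay on cells (Homo sapiens) for antiproliferative activity, read by MTT assay; a lower number here means a stronger inhibitor, a higher number a weaker inhibitor: 7640 nM
compound 2 `C/C(=N\NC(=O)c1ccc(O)cc1)c1cnccn1` — in this assay: 16800 nM
compound 3 `C/C(=N\NC(=O)c1ccccc1)c1cnccn1` — in this assay: 3620 nM

Among the three numbers, compound 1 stands second highest. Its nearest neighbour is compound 3, which sits lower, and the furthest is compound 2, which sits higher; both gaps lie beyond the scatter. Compound 3 gives the lowest value shown and compound 2 the highest.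

The change to compound 4 `O=C(NN=C(c1ccccn1)c1ccccn1)c1ccccc1` is hydrogen in place of amino on an aromatic carbon. Among the measured compounds shown here, one measured step bears on it: a 4.6-fold lower number from compound 2 to compound 3 (0.67 log units; beyond the scatter), in which a hydroxy group on an aromatic carbon gave way to hydrogen. For the measured compounds named here, that step is the closest precedent for taking a polar substituent off the ring in compound 1, and by analogy a lower number in this assay is expected for compound 4 too. The support is a single step on a different core, so the expected shift is kept somewhat smaller than that of compound 2 to compound 3, while still beyond the scatter.

Compound 4 is estimated at 2600 nM, with a range from 1100 nM to 6500 nM. This estimate corresponds to an expected step of a 2.9-fold lower number from compound 1 to compound 4 (0.47 log units; beyond the scatter).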

Compound 4, half-maximal inhibitory concentration: 3040 nM
For compound 4 the middle estimate is 1.2-fold (0.07 log units) below the measured one; the measured number falls inside the stated range.
By their numbers in this assay, from the lowest: compounds 4 and 3 (each within the scatter of the next); then compound 1; then compound 2.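

In this assay, among the compounds shown here, the step of a 2.5-fold lower number from compound 1 to compound 4 (0.40 log units; beyond the scatter) is the first direct reading at this position on the core of compound 1, and it shows that the amino group, para to a large group, is not required for the activity seen there. Set beside the step of a 4.6-fold lower number from compound 2 to compound 3 (0.67 log units; beyond the scatter) on a different core, it shows the same direction for a second substituent: amino here, hydroxy there, each replaced by hydrogen on an aromatic carbon and each giving a lower number, with no compound shown going against this, though the pattern rests on these two pairs alone. The compounds shown carry no measurement that could account for this shift, so it stands as an observation only.

Still open, on these data alone, is whether any group at this place improves on hydrogen, for example a methoxy group, a fluorine atom, a carboxylic acid or a dimethylamino group. Also open, as far as these compounds go, is whether hydroxy on the core of compound 1, or amino on the core of compound 3, would follow the same direction, which would test whether the two steps reflect one trend across both cores.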